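The compounds below may be only part of what the source reports. "The series", "measured", "known", "first", "only" and "open" are said of these compounds alone.

Among the measured compounds shown here, compound 1 `COc1cc(/C(=C\c2cn(C(C)=O)c3ccc(OCc4ccccc4)cc23)C(=O)O)cc(OC)c1OC` is the first of the three measured compounds. In a functional assay on KB cells (Homo sapiens) for cytotoxicity, read by MTT assay, with a stated time of 72 h (on this read-out lower numbers stand for stronger inhibition and higher numbers for weaker inhibition), compound 1 gives > 100000 nM, which is a limit of the assay and not a number.
Compound 2 `O=C(O)/C(=C/c1c[nH]c2ccc(OCc3ccccc3)cc12)c1ccccc1` gives 55500 nM.
Compound 3 `CC(=O)n1cc(/C=C(/C(=O)O)c2ccccc2)c2cc(OCc3ccccc3)ccc21` gives 55500 nM.

Compound 3 stands level with compound 2 at the digits shown: no change at the digits printed from compound 2 to compound 3 (within the scatter). The other measured step, an at least 1.8-fold lower number from compound 1 to compound 3 (0.25 log units; that floor lies within the scatter), has a floor that rests on the limit recorded for compound 1 (the limit of > 100000 nM in this assay, at which 1 of the 3 values shown sits), so its true size is not known, only that it is not smaller than that floor.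

Compound 4 `COc1ccc(/C(=C\c2cn(C(C)=O)c3ccc(OCc4ccccc4)cc23)C(=O)O)cc1` differs from compound 3 in one place: methoxy in place of hydrogen on an aromatic carbon. For the measured compounds named here, the step that bears on this change is the one from compound 1 to compound 3, in which phenyl replaced 3,4,5-trimethoxyphenyl and the number fell by at least the floor stated. Putting a single methoxy back onto the phenyl of compound 3 might therefore be expected to push the number in the opposite direction, toward that of compound 1, but since the floor of that step lies within the scatter, no step beyond the scatter is expected here; the expected step is a 1.3-fold higher number from compound 3 to compound 4 (0.10 log units; within the scatter). Compound 4 is therefore estimated at 70000 nM, within a range of 30000 nM to 160000 nM, and it is possible that this assay will report only a limit for compound 4.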

Compound 4, half-maximal inhibitory concentration: > 100000 nM
Compound 4 ended at the assay's limit (the forecaster's own chance of this, stated with the estimate: 30%); at least 1.4-fold (0.15 log units) between middle value and limit.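

In this assay, the change from phenyl to 4-methoxyphenyl gives an at least 1.8-fold higher number from compound 3 to compound 4 (0.25 log units; that floor lies within the scatter), which tests one methoxy on its own, para to a large group, whereas the earlier step exchanged the whole 3,4,5-trimethoxyphenyl group for phenyl. As far as these compounds go, this step points the same way as that earlier step, with the methoxy-bearing compound on the higher side, but its floor lies within the scatter, so the compounds do not establish a real effect of the single methoxy, and its true size remains unknown. The step between compound 1 and compound 4 cannot be read, as both compounds rest at the same limit, so the further methoxy groups of compound 1 cannot be assessed: the limit of > 100000 nM in this assay, at which 2 of the 4 values shown sit.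

Still open, from the compounds shown here alone, is whether this response belongs to methoxy in particular or would also appear with a hydroxy, a fluorine or a methyl at the same place on the phenyl. Going by these compounds, it is also open whether 4-methoxyphenyl would behave the same way with hydrogen in place of acetyl on the aromatic nitrogen, or with a methyl ester or an amide in place of the carboxylic acid.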